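Ortho-fluoro on the pendant phenyl in two amide series

The compounds below may be only part of what the source reports. "The series", "measured", "known", "first", "only" and "open" are said of these compounds alone.

Measured compounds in an assay on cell membranes from kidney for displacement of a labelled ligand from Translocator protein (Rattus norvegicus); on this read-out higher numbers stand for weaker inhibition and lower numbers for stronger inhibition:
compound 1 `CCN(Cc1ccc(C)cc1)C(=O)c1nc(-c2ccccc2)c2ccccc2n1`, 2.57 nM;
compound 2 `CCN(Cc1ccc(C)cc1)C(=O)c1nc(-c2ccccc2F)c2ccccc2n1`, 0.6 nM;
compound 3 `CN(Cc1ccccc1)C(=O)c1nc(-c2ccccc2)c2ccccc2n1`, 3.99 nM.

Compound 2 differs from compound 1 by fluoro in place of hydrogen on an aromatic carbon; this change gave a 4.3-fold lower number from compound 1 to compound 2 (0.63 log units; beyond the scatter) in this assay. Compound 3 carries a different amide substitution than compound 1; how the two cores differ is not broken down here. Compound 3 and compound 1 lie within the scatter of each other in this assay.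

Compound 4 `CN(Cc1ccccc1)C(=O)c1nc(-c2ccccc2F)c2ccccc2n1` is not yet measured. It differs from compound 3 by fluoro in place of hydrogen on an aromatic carbon, the same change as from compound 1 to compound 2. Within the data shown here, since the earlier step on compound 1 was a 4.3-fold lower number from compound 1 to compound 2 (0.63 log units; beyond the scatter), a step of the same size is expected here, a 4.0-fold lower number from compound 3 to compound 4 (0.60 log units; beyond the scatter), resting on the single earlier pair. Compound 4 is therefore estimated at 1 nM in this assay, expected between 0.4 nM and 2.5 nM.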

Compound 4, inhibition constant: 1.11 nM
Compound 4: the middle estimate sits 1.1-fold (0.05 log units) below what was measured; the measured number falls inside the stated range.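

In this assay, phenyl to 2-fluorophenyl gave a 3.6-fold lower number from compound 3 to compound 4 (0.56 log units; beyond the scatter), so the change carried over to the second core at much the same size, the two steps agreeing within the scatter: the same change on two cores in this assay, a 4.3-fold lower number (0.63 log units; beyond the scatter) from compound 1 to compound 2 and a 3.6-fold lower number (0.56 log units; beyond the scatter) from compound 3 to compound 4, 1.2-fold (0.08 log units) apart, within the scatter of two such steps

Among these compounds, this agreement rests on only two pairs, and their cores differ only in the amide substitution. It therefore shows nothing about cores altered elsewhere, and it does not tell why the fluoro lowers the number.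

The compounds shown leave open whether chloro or methoxy in place of the fluoro would give a step of like size. They also leave open whether the step would hold with a longer chain or a carboxylic acid on the amide substituent.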